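The compounds below may be only part of what the source reports. "The series", "measured", "known", "first", "only" and "open" are said of these compounds alone.

The measured compounds:

Compound 1, `COc1cc2c(Oc3ccc(NC(=O)c4cc(-c5ccc(C(F)(F)F)cc5)ccn4)cc3F)ccnc2cc1OCCCN1CCCCC1`: 360 nM
Compound 2, `COc1ccc(-c2ccnc(C(=O)Nc3ccc(Oc4ccnc5cc(OCCCN6CCCCC6)c(OC)cc45)c(F)c3)c2)cc1`: 200 nM
Compound 3, `COc1cc2c(Oc3ccc(NC(=O)c4cc(-c5ccc(F)cc5)ccn4)cc3F)ccnc2cc1OCCCN1CCN(C)CC1`: 430 nM

These three share one core and were tested in a functional assay on NCI-H460 cells (Homo sapiens) for cytotoxicity, read by MTT assay, with a stated time of 72 h; a higher number here means a weaker inhibitor, a lower number a stronger inhibitor. Compound 2 has the lowest number of the three; compound 1 sits a 1.8-fold lower number from compound 1 to compound 2 (0.26 log units; within the scatter) away from it, a gap within the scatter, while compound 3 lies further off, beyond the scatter. Compound 2 thus stands at the favourable end, though it cannot be set apart from compound 1.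

The step to compound 4, `COc1ccc(-c2ccnc(C(=O)Nc3ccc(Oc4ccnc5cc(OCCCN6CCN(C)CC6)c(OC)cc45)c(F)c3)c2)cc1`, changes one place: 4-methylpiperazin-1-yl in place of piperidin-1-yl on a saturated chain carbon, three bonds along the chain from an oxygen on an aromatic ring. Within the data shown here, no measured pair differs in this place alone. The closest comparison is between compound 1 and compound 3, which differ in two places, this one among them; compound 1 gives 360 nM and compound 3 gives 430 nM, values within the scatter of each other. On that slim basis no step beyond the scatter is expected in this assay, in either direction. Compound 4 is therefore estimated at 250 nM, within 120 nM to 520 nM, meaning an expected step of a 1.3-fold higher number from compound 2 to compound 4 (0.10 log units; within the scatter).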

Compound 4, half-maximal inhibitory concentration: 370 nM
Estimate against measurement, compound 4: 1.5-fold (0.17 log units) below, and the stated range covers the measured number.
By their numbers in this assay, from the lowest: compounds 2, 1, 4 and 3 (each within the scatter of the next, the first and the last beyond it).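

In this assay, among these compounds, the pair of compound 2 and compound 4 isolates this position for the first time: 4-methylpiperazin-1-yl in place of piperidin-1-yl, on a saturated chain carbon three bonds along the chain from an oxygen on an aromatic ring, gives a 1.9-fold higher number from compound 2 to compound 4 (0.27 log units; within the scatter) and so no step that can be told from assay noise. With 4-methylpiperazin-1-yl held in place, methoxy in place of fluoro on an aromatic carbon gives a 1.2-fold lower number from compound 3 to compound 4 (0.07 log units; within the scatter) and is likewise no clear change.

Both rings at the chain end thus fit the same range of numbers here, but two rings are a narrow sample. From the compounds shown here alone, a morpholine ring, an open-chain dimethylamine or a carboxylic acid at the chain end remains open, as does a longer chain. Nothing available here explains these numbers.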